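Moving Chlorines Around: What Compound 4 Might Show

This account rests on a few compounds, and the source may have more. Where it says the series, first, only, none or still open, it means among the compounds named here.

Compound 1, `COc1cccc(/C=C2\CCC/C(=C\c3ccc(Cl)cc3)C2=O)c1OC`, in a functional assay on A549 cells (Homo sapiens) for cytotoxicity, read by MTT assay, with a stated time of 72 h (a lower number here means a stronger inhibitor, a higher number a weaker inhibitor), gives > 20000 nM, a limit of the assay rather than a number.
Compound 2, `COc1cccc(/C=C2\CCC/C(=C\c3ccc(Br)cc3)C2=O)c1OC`, in this assay gives > 20000 nM, again a limit.
Compound 3, `COc1cccc(/C=C2\CCC/C(=C\c3ccc(Cl)c(Cl)c3)C2=O)c1OC`, in this assay gives > 20000 nM, also a limit.

Compound 2 therefore stands only at a limit in this assay, and the two other values shown stand at the same limit. The steps a step that the two limits leave unreadable from compound 1 to compound 2, a step that the two limits leave unreadable from compound 1 to compound 3 and a step that the two limits leave unreadable from compound 2 to compound 3 are all unreadable, since (the limit of > 20000 nM in this assay, at which 3 of the 3 values shown sit). Compound 4, `COc1cccc(/C=C2\CCC/C(=C\c3cc(Cl)cc(Cl)c3)C2=O)c1OC`, is not yet measured; it differs from compound 2 in this way: 3,5-dichlorophenyl in place of 4-bromophenyl on a double-bonded chain carbon bound to a double-bonded ring carbon. Among the measured compounds shown here, no measured step bears readably on this change, and every value of the series sits at the limit. It is therefore expected that the step that the limit leaves unreadable from compound 2 to compound 4 lies at or around the limit as well, with no direction readable. The estimate for compound 4 in this assay is 30000 nM, within a range from 10000 nM to 100000 nM.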

Compound 4, half-maximal inhibitory concentration: 12500 nM
Compound 4: the middle estimate sits 2.4-fold (0.38 log units) above what was measured; the measured number falls inside the stated range.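

In this assay, among the compounds shown here, compound 4 gives the first number of the series rather than a limit, so the change to 3,5-dichlorophenyl on a double-bonded chain carbon bound to a double-bonded ring carbon can at last be sized, with an at least 1.6-fold lower number from compound 2 to compound 4 (0.20 log units; that floor lies within the scatter) and an at least 1.6-fold lower number from compound 3 to compound 4 (0.20 log units; that floor lies within the scatter) and an at least 1.6-fold lower number from compound 1 to compound 4 (0.20 log units; that floor lies within the scatter) as its readable steps. The step from compound 3 is the one in which the two chlorines stay and only their arrangement differs, but all three steps are floors within the scatter, and the steps among compounds 1, 2 and 3 still cannot be read. The true sizes stay hidden because the other compounds all sit at one limit: the limit of > 20000 nM in this assay, at which 3 of the 4 values shown sit.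

As far as these compounds go, whether an amine or a carboxylic acid in place of one chlorine of the 3,5-dichlorophenyl group would shift the number stays open. So does whether a 3,5-dibromophenyl group would match compound 4.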